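Swapping an Acetamidophenyl for a Cyclopropylsulfonyl Pyrrolidinyl

A few compounds are considered here, and "the series" means these few. Any claim that something is new, unique, unknown or untested is made for them only; others in the source may bear on it.

Compound 1 `CN1CCN(c2ccc(Nc3ncc4nc(Nc5ccccc5)n([C@H]5CCN(S(C)(=O)=O)C5)c4n3)cc2)CC1`: "not determined" (no result reported) in a functional assay on A-431 cells (Homo sapiens) for antiproliferative activity, read by MTT assay, with a stated time of 72 h; a lower number here means a stronger inhibitor, a higher number a weaker inhibitor
Compound 2 `CC(=O)Nc1cccc(-n2c(Nc3ccc(F)cc3)nc3cnc(Nc4ccc(N5CCN(C)CC5)cc4)nc32)c1`: "not determined" (no result reported) in this assay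
Compound 3 `CN1CCN(c2ccc(Nc3ncc4nc(Nc5ccccc5)n([C@H]5CCN(S(=O)(=O)C6CC6)C5)c4n3)cc2)CC1`: 1670 nM

Compound 2 stands without a number in this assay, recorded as "not determined" (no result reported); it shares that gap with compound 1, recorded as "not determined" (no result reported), so only compound 3 offers a measured point of reference. Compound 4 `CN1CCN(c2ccc(Nc3ncc4nc(Nc5ccc(F)cc5)n([C@@H]5CCN(S(=O)(=O)C6CC6)C5)c4n3)cc2)CC1` has not yet been measured. It differs from compound 2 by 1-(cyclopropylsulfonyl)pyrrolidin-3-yl in place of 3-acetamidophenyl on an aromatic nitrogen. Within the data shown here, no step between measured compounds is given, so the size of the step from compound 2 to compound 4 in this assay cannot be read from a printed pair; the nearest guide is compound 3, which gives 1670 nM and shares the entering group. For compound 4 the expected value is 1500 nM, in a range from 400 nM to 6000 nM.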

Compound 4, half-maximal inhibitory concentration: > 10000 nM
Compound 4: only a limit was reported; the forecaster's own chance of this, stated with the estimate: 10%; at least 6.6-fold (0.82 log units) between middle value and limit.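

No step can be read between compound 2, which has no single number in this assay, and compound 4. Compound 4 gives > 10000 nM, which is a limit. The compounds shown leave open what swapping 3-acetamidophenyl for 1-(cyclopropylsulfonyl)pyrrolidin-3-yl does in this assay.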